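A few compounds are considered here, and "the series" means these few. Any claim that something is new, unique, unknown or untested is made for them only; others in the source may bear on it.

Measured compounds:

Compound 1 `O=C(Nc1ncc(C(Oc2ccc3cc(Br)ccc3c2)c2ccc(Cl)cc2)s1)C1CCCO1` gives "not toxic" (no number reported) in an ADME assay on HepG2 2.2.15 cells (Homo sapiens) for cytotoxicity; a lower number here means that less compound is tolerated, a higher number that more compound is tolerated.
Compound 2 `O=C(Nc1ncc(C(Oc2ccc3cc(Br)ccc3c2)c2ccc(Cl)cc2)s1)c1ccccc1` gives "not toxic" (no number reported) in this assay.
Compound 3 `O=S(=O)(Nc1ncc(C(Oc2ccc3cc(Br)ccc3c2)c2ccc(Cl)cc2)s1)c1ccccc1` gives > 50000 nM in this assay, which is a limit of the assay and not a number.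

Compound 3 therefore stands at the upper edge of what the assay reports; the two further entries, for compound 1 and compound 2, carry no number at all. For the measured compounds named here, no step between two measured compounds can be computed, so nothing is known about how any single change has shifted tolerance in this assay. What can be said is that (the limit of > 50000 nM in this assay, at which 1 of the 3 values shown sits), and that all three entries point the same way, towards the untoxic end.

Compound 4 `Cc1ccc(S(=O)(=O)Nc2ncc(C(Oc3ccc4cc(Br)ccc4c3)c3ccc(Cl)cc3)s2)c2ccccc12` is the next member: 4-methylnaphthalen-1-yl in place of phenyl on a sulfonyl sulfur. The step from compound 3 to compound 4 is expected to show no shift beyond the scatter, since compound 3 already sits at the limit and compound 1 and compound 2 give the same kind of reading; this is the expectation printed as a step that the limit leaves unreadable from compound 3 to compound 4. Compound 4 is expected to give about 60000 nM in this assay, with a range from 20000 nM to 200000 nM, most probably again reported only as a limit.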

Compound 4, half-maximal cytotoxic concentration: > 50000 nM
Compound 4 gave a limit, no number (the forecaster's own chance of this, stated with the estimate: 70%); the middle value lies beyond the limit too.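

In this assay no step can be read from compound 3 to compound 4 because both entries are limits: the limit of > 50000 nM in this assay, at which 2 of the 4 values shown sit. The compounds shown leave open where the tolerated concentration of any of them lies, and whether 4-methylnaphthalen-1-yl in place of phenyl on a sulfonyl sulfur shifts it at all.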